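Replacing a vinyl group with an amino alcohol chain

The compounds below may be only part of what the source reports. "The series", "measured", "known", "first", "only" and "open" are said of these compounds alone.

Measured compounds:
compound 1, `CCCCCCCCCO[C@@H]1[C@@H](N)[C@@H](OC[C@H](O)CN=[N+]=[N-])O[C@H](CN)[C@H]1OCCCCCCCCC`, 5.9%
compound 2, `CCCCCCCCCO[C@@H]1[C@@H](N)[C@@H](OCC(O)CNCCO)O[C@H](CN)[C@H]1OCCCCCCCCC`, 10.1%
compound 3, `C=CCO[C@H]1O[C@H](CN)[C@@H](OCCCCCCCCC)[C@H](OCCCCCCCCC)[C@H]1N`, 6.6%

All three were tested in a toxicity assay on the whole organism (J774 cells) for cytotoxicity, with Mus musculus as the target, read by MTT assay, with a stated time of 24 h, tested at 30 uM; a higher number here means a weaker effect of the compound at the concentration tested, a lower number a stronger effect. Compound 3 sits close to both others: the gap a number 0.7 percentage points higher from compound 1 to compound 3 (within the scatter) and the gap a number 3.5 percentage points lower from compound 2 to compound 3 (within the scatter) are both small, so no ordering among the three can be claimed.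

Compound 4, `CCCCCCCCCO[C@@H]1[C@@H](N)[C@@H](OC[C@H](O)CN)O[C@H](CN)[C@H]1OCCCCCCCCC`, is not yet measured. It differs from compound 3 by 2-amino-1-hydroxyethyl in place of vinyl on a saturated chain carbon bound to an oxygen on a saturated carbon.

Among the compounds with values here, two measured steps bear on this change, since they also swap the vinyl group for a hydroxylated side chain carrying nitrogen: a number 0.7 percentage points higher from compound 1 to compound 3 (within the scatter) and a number 3.5 percentage points lower from compound 2 to compound 3 (within the scatter), both within the scatter. The step to compound 4 is therefore expected to stay within the scatter too, a number 1.4 percentage points higher from compound 3 to compound 4 (within the scatter). Compound 4 is thus estimated at 8%, likely between 2% and 16%.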

Compound 4, a percentage reported as activity, at one concentration (the size of the read-out at that concentration, not a potency): 14.4%
The estimate for compound 4 lay 6.4 percentage points below the measured number, and the stated range covers the measured number.
By their numbers in this assay, from the lowest: compounds 1, 3, 2 and 4 (each within the scatter of the next).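

In this assay the new side chain gives three steps, a number 7.8 percentage points higher from compound 3 to compound 4 (within the scatter) and a number 4.3 percentage points higher from compound 2 to compound 4 (within the scatter) and a number 8.5 percentage points higher from compound 1 to compound 4 (within the scatter). A terminal amino group on this chain therefore cannot be told apart from vinyl, azido or the 2-hydroxyethylamino end at this position, so all four groups remain equivalent within the scatter. Nothing available explains these numbers. Still open, as far as these compounds go, is whether a carboxylic acid at the end of this chain, or a longer chain carrying the amine, would give a step beyond the scatter.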